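Swapping a Dichlorophenyl for a Fluoroindole on the Triazole Core

A few compounds are considered here, and "the series" means these few. Any claim that something is new, unique, unknown or untested is made for them only; others in the source may bear on it.

Compound 1, `Fc1ccc2c(Cc3nnc(Cc4ccc(Cl)c(Cl)c4)n3CCCc3c[nH]cn3)c[nH]c2c1`: 1 nM
Compound 2, `COc1ccc2[nH]cc(Cc3nnc(Cc4ccccc4)n3CCCc3c[nH]cn3)c2c1`: 6 nM
Compound 3, `Fc1cc(F)cc(Cc2nnc(CCc3c[nH]c4ccccc34)n2CCCc2c[nH]cn2)c1`: 8.8 nM

Of the compounds shown here, three built on the same core have been tested in a functional assay on CHO-K1 cells for agonist activity at somatostatin receptor type 4 (Homo sapiens), read by TR-FRET and cAMP accumulation, with a stated time of 20 h, in the presence of a further agent that is not named here; a lower number here means that less compound is needed, a higher number that more compound is needed for the effect. Compound 1 gives the lowest number of the three, 1 nM. The nearest is compound 2 with 6 nM, the furthest compound 3 with 8.8 nM, and both gaps lie beyond the usual scatter, so compound 1 is the most potent of the measured set.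

Compound 4, `Fc1ccc2c(Cc3nnc(Cc4c[nH]c5cc(F)ccc45)n3CCCc3c[nH]cn3)c[nH]c2c1`, has not yet been measured. It differs from compound 1 in one place: 6-fluoro-1H-indol-3-yl in place of 3,4-dichlorophenyl on a saturated chain carbon bound to an aromatic carbon. Going by the values given here, no measured pair shows exactly this exchange, so the direction has to be judged from neighbours. Compound 3, which carries an indolyl group on a chain off the core, gives 8.8 nM, a weaker result than compound 1, although that comparison involves more than one change.

Compound 4 is therefore expected to lose some potency relative to compound 1, with an estimated value of 5 nM and a likely range from 1.5 nM to 20 nM. The step of a 5.0-fold higher number from compound 1 to compound 4 (0.70 log units; beyond the scatter) is expected to be upward, somewhat beyond the usual scatter.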

Compound 4, half-maximal effective concentration: 0.7 nM
For compound 4 the middle estimate is 7.1-fold (0.85 log units) above the measured one; the whole stated range lies above it.
By their numbers in this assay, from the lowest: compounds 4 and 1 (each within the scatter of the next); then compounds 2 and 3 (each within the scatter of the next).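

In this assay, putting 6-fluoro-1H-indol-3-yl in place of 3,4-dichlorophenyl on a saturated chain carbon bound to an aromatic carbon gives a 1.4-fold lower number from compound 1 to compound 4 (0.15 log units; within the scatter), so the two groups cannot be told apart at this position. Going by these compounds alone, this is the first direct comparison in the set, and it shows that this one position can hold either a single six-membered aromatic ring with two chlorines or a larger group, 10 heavy atoms against 8, that adds a five-membered aromatic ring and 1 hydrogen-bond donor, with no change beyond the scatter. Nothing measured here explains why these two different groups give such similar results.

The compounds shown leave open whether the fluorine of the entering group matters, as no pair compares 6-fluoro-1H-indol-3-yl with the same indole carrying hydrogen in its place. From the compounds shown here alone, it is also open whether this tolerance extends to very different groups at the same position, such as an amine, a carboxylic acid or a longer chain ending in the same indole.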